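Benzyloxy to butoxy on a shared sulfonamide core

The source may report more compounds than this note shows. Statements on the series, on what has been measured and on what is new or still open speak of the compounds shown alone.

Compound 1 `CC1CCN(C2CCN(S(=O)(=O)c3ccc(OCc4ccccc4)cc3)CC2)CC1` was tested in a functional assay on DLD-1 cells (Homo sapiens) for antiproliferative activity, read by CellTiter-Glo, with a stated time of 72 h (a higher number here means a weaker inhibitor, a lower number a stronger inhibitor), where compound 1 gives 385 nM. Among the three compounds measured in this assay, compound 1 stands second highest. Its nearest neighbour is compound 3 `CC(=O)Nc1ccc(S(=O)(=O)N2CCC(N3CCC(C)CC3)CC2)c2ccccc12`, which gives 1100 nM in this assay, a number that lies beyond the scatter from that of compound 1. Furthest away is compound 2 `COc1ccc(Br)cc1S(=O)(=O)N1CCC(N2CCC(C)CC2)CC1`, which gives 2 nM in this assay, a much lower number than that of compound 1.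

Compound 4 `CCCCOc1ccc(S(=O)(=O)N2CCC(N3CCC(C)CC3)CC2)cc1` has not yet been measured in this assay. It differs from compound 1 in one place: propyl in place of phenyl on a saturated chain carbon bound to an oxygen on an aromatic ring. Cut one bond further out, the same difference reads benzyl to butyl, or benzyloxy to butoxy. Among the compounds with values here, no pair of measured compounds shows this change, so the data give no direct guide to its size, and compound 2 and compound 3 differ from compound 1 in other places.

The step expected is a 1.3-fold higher number from compound 1 to compound 4 (0.11 log units; within the scatter), most likely within the scatter or, if anything, toward a weaker inhibitor. The estimate for compound 4 is 500 nM, with a range from 150 nM to 1600 nM.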

Compound 4, half-maximal inhibitory concentration: 2300 nM
Compound 4: the middle estimate sits 4.6-fold (0.66 log units) below what was measured; the measured number lies above the stated range.
By their numbers in this assay, from the lowest: compound 2; then compound 1; then compound 3; then compound 4.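

Benzyloxy to butoxy gives a 6.0-fold higher number from compound 1 to compound 4 (0.78 log units; beyond the scatter) in this assay, the first pair to isolate a change at this place, and it shows that the group on the saturated chain carbon bound to an oxygen on an aromatic ring is not interchangeable, since the step lies beyond the scatter and toward a weaker inhibitor. Here phenyl, with its six-membered aromatic ring of carbon only, leaves and propyl, with no ring and fewer heavy atoms, enters, while neither group carries a hydrogen-bond donor or acceptor, so the pair differs in ring and size alone, and this one pair cannot say which of the two matters. Nothing available bears on why the step has this size.

The compounds shown leave open whether the aromatic ring or the chain itself governs the number, which a cyclohexylmethoxy group, or an ethoxy or hexyloxy chain, on the same core would begin to separate. Also open, from the compounds shown here alone, is how a benzyloxy group carrying a substituent such as an amine or a carboxylic acid on its phenyl ring would read in this assay on this core.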